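Benzhydrazones: furan-2-yl to pyridin-3-yl at the imine carbon

This account rests on a few compounds, and the source may have more. Where it says the series, first, only, none or still open, it means among the compounds named here.

Measured compounds in an assay on liver (Sus scrofa) for inhibition of glucose-6-phosphatase catalytic subunit 1 (Homo sapiens), using microsomes; a lower number here means a stronger inhibitor, a higher number a weaker inhibitor:
- compound 1 `COc1ccc(/C=N/N(Cc2ccccc2)Cc2ccccc2)cc1` gives 220 nM.
- compound 2 `Clc1cc(Cl)cc(/C=N/N(Cc2ccccc2)Cc2ccccc2)c1` gives only a limit of this assay, > 100000 nM.
- compound 3 `C(=N/N(Cc1ccccc1)Cc1ccccc1)\c1ccco1` gives 1100 nM.

Compound 3 holds the higher of the two numbers; its nearest neighbour is compound 1, with a 5.0-fold higher number from compound 1 to compound 3 (0.70 log units; beyond the scatter). Compound 2 sits at the limit of > 100000 nM in this assay, at which 1 of the 3 values shown sits.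

Compound 4 `C(=N/N(Cc1ccccc1)Cc1ccccc1)\c1cccnc1` differs from compound 3 in one place: pyridin-3-yl in place of furan-2-yl on a carbon with a double bond to nitrogen. Among the compounds with values here, three measured steps concern the group on this carbon. a 5.0-fold higher number from compound 1 to compound 3 (0.70 log units; beyond the scatter) was modest, whereas an at least 450-fold higher number from compound 1 to compound 2 (2.65 log units; beyond the scatter) and an at least 90-fold lower number from compound 2 to compound 3 (1.95 log units; beyond the scatter) were large. None of these exchanges a five-membered aromatic ring for a six-membered one, so their bearing is indirect; the gap between compound 1 and compound 3 shows that swapping one aromatic ring with 1 hetero atom for another moved the number only modestly. A step of at most that size, in either direction or none beyond the scatter, is therefore expected in this assay: a 1.4-fold higher number from compound 3 to compound 4 (0.13 log units; within the scatter). For compound 4 the estimate is 1500 nM, with a range from 400 nM to 6000 nM.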

Compound 4, half-maximal inhibitory concentration: 3700 nM
For compound 4 the middle estimate is 2.5-fold (0.39 log units) below the measured one, and the stated range covers the measured number.
By their numbers in this assay, from the lowest: compound 1; then compound 3; then compound 4. At a limit, above all of these: compound 2.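

In this assay, a change of ring size at this carbon is not neutral, even though furan-2-yl and pyridin-3-yl have the same hydrogen-bond donor and acceptor counts: a 3.4-fold higher number from compound 3 to compound 4 (0.53 log units; beyond the scatter). Among the six-membered aromatic rings, the group on this carbon spans a wide range, with a 17-fold higher number from compound 1 to compound 4 (1.23 log units; beyond the scatter) and an at least 27-fold lower number from compound 2 to compound 4 (1.43 log units; beyond the scatter), so a six-membered ring alone does not set the number. Compound 2 gives a limit rather than a number, so its step to compound 4 has no fixed size: the limit of > 100000 nM in this assay, at which 1 of the 4 values shown sits.

The compounds shown do not separate ring size from the identity of the hetero atom, and unsubstituted phenyl or thiophen-2-yl on this carbon would address that. On these data alone, the effect of the ring nitrogen's location, as in pyridin-4-yl, also remains open.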